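The source may hold more compounds than are shown below. What is called first, only, known or untested is meant among the compounds shown, and "the series" means these compounds.

The compounds measured so far in an assay on CHO cells for agonist activity at transient receptor potential cation channel subfamily V member 1 (Homo sapiens); on this read-out higher numbers stand for an effect only at larger amounts of compound and lower numbers for an effect already at smaller amounts:

Compound 1, `CC1CCN(c2nc(C(F)(F)F)ccc2CNC(=O)Nc2cccc3ccc(=O)[nH]c23)CC1`: compound 1 is reported as "not active" (no number reported).
Compound 2, `CC1CCN(c2nc(C(F)(F)F)ccc2CNC(=O)Nc2ccc3ccc(=O)[nH]c3c2)CC1`: compound 2 is reported as "not active" (no number reported).
Compound 3, `O=C(NCc1ccc(C(F)(F)F)nc1N1CCCC1)Nc1cccc2c(=O)[nH]ccc12`: compound 3 gives 258 nM.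

Among the measured compounds shown here, compound 3 is therefore the only member of this small set with a number attached; for compound 1 and compound 2 the report says only that no activity was seen, without a figure, so no ordering against compound 3 can be drawn from them beyond the bare fact that compound 3 did produce a measurable response.

Compound 4, `CC(C)COc1nc(C(F)(F)F)ccc1CNC(=O)Nc1cccc2c(=O)[nH]ccc12`, is not yet measured. It differs from compound 3 in one place: isobutoxy in place of pyrrolidin-1-yl on an aromatic carbon. In plain terms, an isobutoxy group takes the place of a pyrrolidin-1-yl group on an aromatic carbon, a ring of five heavy atoms giving way to a branched chain of the same count, with a nitrogen replaced by an oxygen.

For the measured compounds named here, no pair of measured compounds shows this kind of swap, so the size of the step cannot be read from the data. A change of this sort, on the same core, is expected to move this assay by a modest amount, most likely toward weaker activity, though a result within the scatter would not surprise. The step from compound 3 to compound 4 is estimated as a 2.3-fold higher number from compound 3 to compound 4 (0.37 log units; beyond the scatter). Compound 4 is thus expected to come in at about 600 nM, with a plausible range from 150 nM to 3000 nM.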

Compound 4, half-maximal effective concentration: 78.7 nM
Compound 4: the middle estimate sits 7.6-fold (0.88 log units) above what was measured; the measured number lies below the stated range.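

Swapping pyrrolidin-1-yl for isobutoxy on the aromatic carbon next to the ring nitrogen gives a 3.3-fold lower number from compound 3 to compound 4 (0.52 log units; beyond the scatter) in this assay, the first comparison in this set between two measured numbers. It shows that a ring is not required at this place on the shared core: with the same count of heavy atoms, an open branched chain joined through oxygen gives a response at a smaller amount of compound than the five-membered ring joined through nitrogen. The data shown offer no measured explanation for this gain.

The ring is opened and nitrogen gives way to oxygen in the same step, so the two changes cannot be told apart here; a diethylamino group would keep the nitrogen without the ring, and a cyclopentyloxy group would keep the oxygen with a ring. Steps to compound 1 and compound 2 cannot be read, as each differs from these two compounds in more than one place, and a longer chain such as a hexyloxy group would test how much further this position can be extended.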